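The source may report more compounds than this note shows. Statements on the series, on what has been measured and on what is new or still open speak of the compounds shown alone.

The compounds measured so far:

- compound 1, `CCC(C(=O)N1CCN(c2cccc(Cl)c2)CC1)N1C(=O)CCC1=O`, in a functional assay on the whole organism (strain Swiss) with Mus musculus as the target, in the maximal electroshock model, with a stated time of 0.25 h, at a dose of 300 mg/kg by the intraperitoneal route (on this read-out lower numbers stand for a weaker effect and higher numbers for a stronger effect at the one dose given), compound 1 gives 75%
- compound 2, `CC(C(=O)N1CCN(c2cccc(Cl)c2)CC1)N1C(=O)CCC1=O`, in this assay compound 2 gives 75%
- compound 3, `CCC(C(=O)N1CCN(c2ccccc2)CC1)N1C(=O)CCC1=O`, in this assay compound 3 gives 75%

Compound 2 stands level with its two neighbours. Its nearest relative is compound 1, and the step of no change at the digits printed from compound 1 to compound 2 (within the scatter) shows that trimming the chain did nothing to the read-out. Compound 3 carries the same value as compound 2, so the three share one level within the scatter.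

The new compound 4, `CC(C(=O)N1CCN(c2cccc(F)c2)CC1)N1C(=O)CCC1=O`, is reached from compound 2 by the change (fluoro in place of chloro on an aromatic carbon). One measured step speaks to the same position: from compound 1 to compound 3 the chloro was replaced by hydrogen, and no change at the digits printed from compound 1 to compound 3 (within the scatter). A halogen swapped for another halogen at that carbon is a smaller alteration than a halogen removed altogether, and the removal left the read-out unchanged.

The expectation is therefore no step beyond the scatter: compound 4 is estimated at 75%, with a likely range from 60% to 90%. The expected step of no change at the digits printed from compound 2 to compound 4 (within the scatter) is flat.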

Compound 4, a percentage reported as activity, at one dose (the size of the read-out at that dose, not a potency): 100%
Estimate against measurement, compound 4: 25 percentage points below, and the stated range ends below it.
By their numbers in this assay, from the lowest: compounds 1, 2 and 3 (each within the scatter of the next); then compound 4.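

In this assay, among these compounds, putting fluoro in place of chloro on this aromatic carbon gives a number 25 percentage points higher from compound 2 to compound 4 (beyond the scatter), the first step to pass beyond the scatter. The earlier step, no change at the digits printed from compound 1 to compound 3 (within the scatter), made this carbon look indifferent to what it carries, but the new result shows that the group there can change the read-out and that one halogen cannot be assumed to stand in for another. Nothing at hand explains why 3-fluorophenyl and 3-chlorophenyl differ here.

On these data alone, what a bromo or a methoxy group would do on the same carbon remains open. As far as these compounds go, it is also open whether fluoro would bring a similar rise on the longer chain of compound 1, or whether the gain depends on the shorter chain of compound 2.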